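From Sulfonamide to Amide on a Cytotoxic Core

This account rests on a few compounds, and the source may have more. Where it says the series, first, only, none or still open, it means among the compounds named here.

Compound 1 `O=S(=O)(NCCCNc1nccc(-c2c(-c3cccc(F)c3)nc3sccn23)n1)c1ccc(F)cc1` carries (((4-fluorophenyl)sulfonyl)amino)methyl on a saturated chain carbon, two bonds along the chain from a nitrogen on an aromatic ring. In a functional assay on SK-MEL-28 cells (Homo sapiens) for cytotoxicity, read by MTT assay (a lower number here means a stronger inhibitor, a higher number a weaker inhibitor), compound 1 reaches only the limit of the measurement, > 20000 nM, so no exact number is known for it. Compound 2 `O=S(=O)(NCCNc1nccc(-c2c(-c3cccc(F)c3)nc3sccn23)n1)c1ccccc1` carries (phenylsulfonyl)amino at that place; in this assay compound 2 gives 19000 nM. The step of an at least 1.0-fold lower number from compound 1 to compound 2 (0.02 log units; that floor lies within the scatter) lies within the scatter, so these two compounds cannot be told apart on the numbers shown. Compound 3 `Cc1ccc(C(=O)NCCNc2nccc(-c3c(-c4cccc(F)c4)nc4sccn34)n2)cc1` has not yet been measured. Its change from compound 1 is ((4-methylphenyl)carbonyl)amino in place of (((4-fluorophenyl)sulfonyl)amino)methyl on a saturated chain carbon, two bonds along the chain from a nitrogen on an aromatic ring. Among the measured compounds shown here, only the step from compound 1 to compound 2 bears on this change, and because compound 1 sits at the limit of > 20000 nM in this assay, at which 1 of the 2 values shown sits, that step carries no real size. Both measured compounds are weak inhibitors, and nothing measured points toward a gain. Compound 3 is therefore expected to stay weak, with an estimated step of a number no higher from compound 1 to compound 3 (the limit leaves the size open) that remains within the scatter. The estimate for compound 3 in this assay is 20000 nM, with a range from 7000 nM to 60000 nM.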

Compound 3, half-maximal inhibitory concentration: 18800 nM
Compound 3: middle estimate off by 1.1-fold (0.03 log units), on the high side; measured number inside the range.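

In this assay, putting (4-methylphenyl)carbonyl in place of phenylsulfonyl on an amine nitrogen gives a 1.0-fold lower number from compound 2 to compound 3 (0.00 log units; within the scatter), so on this chain the amide of compound 3 and the sulfonamide of compound 2 cannot be told apart. The wider change, ((4-methylphenyl)carbonyl)amino in place of (((4-fluorophenyl)sulfonyl)amino)methyl, gives an at least 1.0-fold lower number from compound 1 to compound 3 (0.02 log units; that floor lies within the scatter). Compound 1 has only a limit rather than a number, so the true size of that step stays unknown: the limit of > 20000 nM in this assay, at which 1 of the 3 values shown sits.

As far as these compounds go, these three compounds all carry an aromatic ring at the end of the chain, so it remains open whether a different end group, such as a free amine, a morpholine or a carboxylic acid, would give a clearly lower number in this assay. From the compounds shown here alone, it is also open whether the amide of compound 3 would behave the same way on a longer chain, or whether a small alkyl group such as methyl or a methoxy group on its ring in place of the 4-methyl would move the number beyond the usual scatter.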